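This account rests on a few compounds, and the source may have more. Where it says the series, first, only, none or still open, it means among the compounds named here.

The study measures inhibition of the enzyme in an assay for inhibition of 3-hydroxy-3-methylglutaryl-coenzyme A reductase (Rattus norvegicus); a lower number here means a stronger inhibitor, a higher number a weaker inhibitor. Compound 1, `O=C1C[C@H](O)C[C@@H](/C=C/c2c(Cl)cc(Cl)cc2CCc2ccccc2)O1`, carries a phenethyl group on its aromatic ring, and in this assay compound 1 gives 430 nM. That is the highest of the three numbers recorded. Compound 2, `Cc1cc(-c2cccc(Cl)c2/C=C/[C@@H]2C[C@@H](O)CC(=O)O2)ccc1F`, gives 30 nM in this assay, and compound 3, `Cc1cc(C)c(/C=C/[C@@H]2C[C@@H](O)CC(=O)O2)c(-c2cc(C)c(F)c(C)c2)c1`, gives 10 nM; both of these lie far below compound 1, well beyond the scatter of repeated measurement. Both compounds 2 and 3 differ from compound 1 in bearing a second aromatic ring bonded directly to the core rather than through a two-carbon chain.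

Compound 4, `COc1cccc(-c2cc(Cl)cc(Cl)c2/C=C/[C@@H]2C[C@@H](O)CC(=O)O2)c1`, has not yet been measured. It differs from compound 1 in one place: 3-methoxyphenyl in place of phenethyl on an aromatic carbon. With this change compound 4 joins compounds 2 and 3 in presenting a directly attached aryl group on the core.

Within the data shown here, no measured pair shows this exact exchange, so the size of the step must be inferred. Given that compounds 2 and 3 sit so far below compound 1, a large step downward, clearly beyond the scatter, is expected for compound 4, amounting to a 14-fold lower number from compound 1 to compound 4 (1.16 log units; beyond the scatter). Compound 4 is therefore estimated at 30 nM in this assay, within a range of 8 nM to 120 nM.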

Compound 4, half-maximal inhibitory concentration: 50 nM
Compound 4: the middle estimate sits 1.7-fold (0.22 log units) below what was measured; low and high end bracket the measured number.
By their numbers in this assay, from the lowest: compound 3; then compounds 2 and 4 (each within the scatter of the next); then compound 1.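

In this assay, replacing phenethyl with 3-methoxyphenyl on an aromatic carbon of the core gives an 8.6-fold lower number from compound 1 to compound 4 (0.93 log units; beyond the scatter), the only step shown in which just one place differs, so this position clearly responds to the group it carries. The two groups each contain one six-membered aromatic ring of carbon only and have the same count of heavy atoms, yet the entering group has its ring attached directly, with a methoxy group and a hydrogen-bond acceptor added, so this single step combines several differences and cannot assign the gain to any one of them. Nothing shown here gives a measured reason for the size of this step.

The compounds shown leave open how much of the step belongs to removing the two-carbon link and how much to the methoxy group, a question that plain phenyl or benzyl on the core of compound 1 would address. They also leave open whether 4-methoxyphenyl or 3-hydroxyphenyl in this place would give a number apart from that of compound 4 at 50 nM.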